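Swapping the pendant phenyl substituent on the pyrazole core

The source may hold more compounds than are shown below. What is called first, only, known or untested is meant among the compounds shown, and "the series" means these compounds.

Measured compounds:
- compound 1 `Cc1nn(-c2nc(-c3ccc(Cl)c(Cl)c3)c(SC(C)C)s2)c(C(=O)O)c1-c1cccc(F)c1`: 900 nM
- compound 2 `Cc1cc(C)cc(-c2c(C)nn(-c3nc(-c4ccc(Cl)c(Cl)c4)c(SC(C)C)s3)c2C(=O)O)c1`: 2700 nM
- compound 3 `Cc1cccc(-c2c(C)nn(-c3nc(-c4ccc(Cl)c(Cl)c4)c(SC(C)C)s3)c2C(=O)O)c1`: 17000 nM

All three share one core and differ only in the aryl ring attached to it. In a functional assay on BJAB cells (Homo sapiens) for antiproliferative activity, with a stated time of 4 days (a higher number here means that more compound is needed for the effect, a lower number that less compound is needed), compound 1 gives 900 nM, compound 2 gives 2700 nM and compound 3 gives 17000 nM. Compound 3 thus stands at the top of the three numbers: it is separated from compound 2 by a 6.3-fold higher number from compound 2 to compound 3 (0.80 log units; beyond the scatter) and from compound 1 by a 19-fold higher number from compound 1 to compound 3 (1.28 log units; beyond the scatter), both steps lying beyond the scatter, so compound 3 needs the most material of the three.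

Compound 4 `Cc1nn(-c2nc(-c3ccc(Cl)c(Cl)c3)c(SC(C)C)s2)c(C(=O)O)c1-c1ccccc1Cl` is not yet measured. It differs from compound 3 by 2-chlorophenyl in place of 3-methylphenyl on an aromatic carbon. Going by the values given here, no measured pair tests a 2-chlorophenyl ring directly. The nearest guide is the pair of compounds 1 and 3, where a halogen-bearing ring in place of a methyl-bearing one gave a 19-fold higher number from compound 1 to compound 3 (1.28 log units; beyond the scatter), a large change, and the pair of compounds 2 and 3, where adding a methyl gave a 6.3-fold higher number from compound 2 to compound 3 (0.80 log units; beyond the scatter). Since a halogen replaces the methyl here, a lower number in this assay is expected for compound 4, though the different substituent position leaves the size uncertain; the expected step is a 4.9-fold lower number from compound 3 to compound 4 (0.69 log units; beyond the scatter). Compound 4 is estimated at 3500 nM, within a range of 800 nM to 15000 nM.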

Compound 4, half-maximal effective concentration: 13100 nM
Compound 4: the middle estimate sits 3.7-fold (0.57 log units) below what was measured, within the range that was stated.
By their numbers in this assay, from the lowest: compound 1; then compound 2; then compounds 4 and 3 (each within the scatter of the next).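

In this assay, a halogen on the aryl ring does not by itself bring a low number: 2-chlorophenyl and 3-methylphenyl cannot be told apart, with a 1.3-fold lower number from compound 3 to compound 4 (0.11 log units; within the scatter) between them. The two halogen-bearing compounds also lie far apart, with a 15-fold higher number from compound 1 to compound 4 (1.16 log units; beyond the scatter) on the step from the 3-fluorophenyl ring, while a 4.9-fold higher number from compound 2 to compound 4 (0.69 log units; beyond the scatter) shows that the 3,5-dimethylphenyl ring also keeps a clear lead over 2-chlorophenyl, so the presence of a halogen does not sort these four compounds. Nothing measured here explains why these rings differ.

The compounds shown leave open whether fluorine and chlorine would give similar numbers at one and the same place on the ring, since compound 1 and compound 4 differ in both the halogen and where it sits. They also leave open how this ring would behave if it carried a group of a different kind, such as an amine or a methoxy group, rather than only halogen or methyl substituents.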